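Bromo substitution on the fused benzene ring of two cores

The source may hold more compounds than are shown below. What is called first, only, known or untested is meant among the compounds shown, and "the series" means these compounds.

Compound 1 `CCN(CC)CN1C(=O)/C(=N\c2nc3ccc(C)cc3s2)c2ccccc21` and compound 2 `CCN(CC)CN1C(=O)/C(=N\c2nc3ccc(C)cc3s2)c2c(Br)cccc21` share one core. In a functional assay on MDA-MB-231 cells (Homo sapiens) for cytotoxicity, read by sulforhodamine B assay, with a stated time of 48 h (a higher number here means a weaker inhibitor of growth, a lower number a stronger inhibitor of growth), compound 1 gives 32700 nM, and compound 2 gives 28700 nM. The change between them is bromo in place of hydrogen on an aromatic carbon and the step it made is a 1.1-fold lower number from compound 1 to compound 2 (0.06 log units; within the scatter).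

Compound 3 `O=C1C(=O)N(CN(c2ccccc2)c2ccccc2)c2ccccc21` carries a different core; how the two cores differ is not broken down here. In this assay compound 3 gives 24800 nM, a value within the scatter of both compound 1 and compound 2.

Compound 4 `O=C1C(=O)N(CN(c2ccccc2)c2ccccc2)c2cccc(Br)c21` differs from compound 3 by bromo in place of hydrogen on an aromatic carbon, the same change as that from compound 1 to compound 2, at a place described in the same words. For compound 4 the step of a 1.1-fold lower number from compound 3 to compound 4 (0.05 log units; within the scatter) is expected to be small, because the measured step of a 1.1-fold lower number from compound 1 to compound 2 (0.06 log units; within the scatter) was within the scatter. Compound 4 is therefore estimated at 22000 nM, with a range from 11000 nM to 45000 nM.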

Compound 4, concentration for 50% growth inhibition: 51100 nM
The estimate for compound 4 lay 2.3-fold (0.37 log units) below the measured number; measured number above the stated range.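

In this assay, bromo in place of hydrogen on an aromatic carbon gives a 2.1-fold higher number from compound 3 to compound 4 (0.31 log units; beyond the scatter), a modest weakening of growth inhibition on the core of compound 3. Set beside the earlier step, the outcome of this change does not separate the two cores: the same change on two cores in this assay, a 1.1-fold lower number (0.06 log units; within the scatter) from compound 1 to compound 2 and a 2.1-fold higher number (0.31 log units; beyond the scatter) from compound 3 to compound 4, 2.3-fold (0.37 log units) apart, within the scatter of two such steps. This pair of steps therefore neither shows that the change carries from one core to the other with the same outcome nor shows that the core alters it, and it rests on a single step per core.

As far as these compounds go, it remains open whether chloro, fluoro or an amine in place of hydrogen on the same aromatic carbon would follow bromo on either core. From the compounds shown here alone, whether either step holds in other cell lines is also open.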